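The source may hold more compounds than are shown below. What is called first, only, known or untested is meant among the compounds shown, and "the series" means these compounds.

In an ADME assay on L929 cells (Mus musculus) for cytotoxicity, read by resazurin assay, with a stated time of 96 h (a higher number here means that more compound is tolerated, a lower number that less compound is tolerated), compound 1 (`CNC(=S)N/N=C(/COc1ccc(Br)cc1)c1ccc(F)cc1`) gives "not determined" (no result reported) and so offers no number for comparison. In this assay compound 2 (`NC(=S)N/N=C(\COc1ccccc1)c1ccc(Br)cc1`) gives 54900 nM and compound 3 (`COc1cccc(OC/C(=N\NC(N)=S)c2ccc(Br)cc2)c1`) gives 50700 nM so these two values lie within the scatter of each other. Going by the values given here, compound 2 therefore stands level with the only other measured member of the series.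

Among the compounds with values here, compound 4 (`CC(=O)Nc1ccc(OC/C(=N\NC(N)=S)c2ccc(Br)cc2)cc1`) differs from compound 2 by acetamido in place of hydrogen on an aromatic carbon as its one change, acetamido in place of hydrogen on an aromatic carbon. The nearest measured evidence is the methoxy in place of hydrogen on an aromatic carbon, which gave a 1.1-fold lower number from compound 2 to compound 3 (0.03 log units; within the scatter) as its step. Within the data shown here, that is a single step with a different group, and no measured compound carries acetamido, so the support is thin.

No step beyond the scatter is expected in this assay and no direction is favoured. The estimated move is a 1.1-fold lower number from compound 2 to compound 4 (0.04 log units; within the scatter) and it is held loosely. For compound 4 the expected value is 50000 nM with an estimated range from 22000 nM to 110000 nM in this series.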

Compound 4, half-maximal cytotoxic concentration: 94900 nM
Estimate against measurement, compound 4: 1.9-fold (0.28 log units) below; low and high end bracket the measured number.
By their numbers in this assay, from the lowest: compounds 3, 2 and 4 (each within the scatter of the next).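

Acetamido, with its 4 heavy atoms and one hydrogen-bond donor and acceptor, sits on an aromatic carbon para to a large group and gives a 1.7-fold higher number from compound 2 to compound 4 (0.24 log units; within the scatter) in this assay. The earlier step, a 1.1-fold lower number from compound 2 to compound 3 (0.03 log units; within the scatter), concerned only methoxy, so this result extends the picture to a larger group at this place without a shift beyond the scatter. Nothing at hand explains the size or direction of this step.

Still open, going by these compounds, is whether a group such as an amine or a carboxylic acid on this same aromatic carbon would also remain within the scatter of compound 2. It is equally unclear whether a longer chain in place of the acetyl part of acetamido would give a number beyond the scatter in this assay.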